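The source may report more compounds than this note shows. Statements on the series, on what has been measured and on what is new or still open speak of the compounds shown alone.

Compound 1, `COc1cccc(N2CCN(C(=O)C(C)N3C(=O)CCC3=O)CC2)c1`, is one of two measured members of a small series in which the group on an amine nitrogen in a ring is varied. In a functional assay on the whole organism (strain Swiss) with Mus musculus as the target, in the maximal electroshock model, with a stated time of 2 h, at a dose of 300 mg/kg by the intraperitoneal route (a lower number here means a weaker effect, a higher number a stronger effect of the compound at the dose given), compound 1 gives 0%. Within the data shown here, its only measured neighbour is compound 2, `CC(C(=O)N1CCN(c2ccc(Cl)cc2)CC1)N1C(=O)CCC1=O`, which in this assay gives 0%. Among the measured compounds shown here, the single step between them, no change at the digits printed from compound 1 to compound 2 (within the scatter), therefore shows that the exchange of 3-methoxyphenyl for 4-chlorophenyl on the amine nitrogen in the ring leaves the read-out where it was. Compound 1 thus stands level with compound 2, both at the floor of the scale.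

Compound 3, `CC(C(=O)N1CCN(c2ccc(F)cc2)CC1)N1C(=O)CCC1=O`, is the next member to be tested. It differs from compound 1 in one place: 4-fluorophenyl in place of 3-methoxyphenyl on an amine nitrogen in a ring. For the measured compounds named here, the only step that bears on this change is the one from compound 1 to compound 2, which did not move the read-out beyond the scatter; a 4-fluorophenyl on the same ring nitrogen is an exchange of the same kind, and nothing measured here points the other way. The account therefore expects no step beyond the scatter in this assay, that is no change at the digits printed from compound 1 to compound 3 (within the scatter), for compound 3. For compound 3 the estimated value in this assay is 0%, with a range from 0% to 15%.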

Compound 3, a percentage reported as activity, at one dose (the size of the read-out at that dose, not a potency): 50%
For compound 3 the middle estimate is 50 percentage points below the measured one, outside the stated range (above it).
By their numbers in this assay, from the lowest: compounds 1 and 2 (each within the scatter of the next); then compound 3.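

The position on the amine nitrogen in the ring is not indifferent in this assay as the earlier pair had suggested, since the exchange of 3-methoxyphenyl for 4-fluorophenyl gives a number 50 percentage points higher from compound 1 to compound 3 (beyond the scatter) in this series. The shared core can therefore carry a read-out above the floor when this group changes, and the earlier lack of change between compound 1 and compound 2 did not hold for every aryl group at this place. The more telling comparison is the exchange on the aromatic carbon alone, fluoro in place of chloro, which gives a number 50 percentage points higher from compound 2 to compound 3 (beyond the scatter) and so separates two otherwise identical compounds through one halogen. No measurement at hand accounts for this step.

On these data alone, it remains open whether the higher read-out belongs to the fluoro group itself or would also appear with an unsubstituted phenyl, a 4-bromophenyl, a 4-methoxyphenyl or a 3-fluorophenyl on the same nitrogen. As far as these compounds go, it also remains open how compound 3 behaves at other doses or other times, since a single read-out at one dose gives no potency.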